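The source may report more compounds than this note shows. Statements on the series, on what has been measured and on what is new or still open speak of the compounds shown alone.

Of the compounds shown here, three sharing one core have been tested in an ADME assay on NIH3T3 cells (Mus musculus) for cytotoxicity, read by MTT assay, with a stated time of 24 h; a lower number here means a stronger inhibitor, a higher number a weaker inhibitor. Compound 1 `Cc1nnc(SCC(=O)N/N=c2/scc(-c3ccccc3)n2-c2ccccc2)s1` gives 197 ug/mL. Compound 2 `O=C(CSc1nnnn1-c1ccccc1)N/N=c1/scc(-c2ccc(Br)cc2)n1-c1ccccc1` gives 433 ug/mL. Compound 3 `Cc1nnc(SCC(=O)N/N=c2/scc(-c3ccc(F)cc3)n2-c2ccccc2)s1` gives 383 ug/mL, which is the second highest of the three numbers; its nearest neighbour is compound 2, and its furthest is compound 1, and both of those gaps lie within the scatter of this assay, so no ordering among the three can be claimed.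

Compound 4 `Cc1nnc(SCC(=O)N/N=c2/scc(-c3ccc([N+](=O)[O-])cc3)n2-c2ccccc2)s1` has not yet been measured. It differs from compound 3 in one place: nitro in place of fluoro on an aromatic carbon, on the six-membered aromatic ring of carbon only, para to a large group.

For the measured compounds named here, only one measured step bears on changes at this position, and only loosely: the step of a 1.9-fold higher number from compound 1 to compound 3 (0.29 log units; within the scatter) shows that putting a fluoro there in place of hydrogen left the number within the scatter. Going by the values given here, no measured compound carries a nitro at any position, so there is no direct guide to how the nitro will behave. Among the compounds with values here, with that single within-scatter step as the only precedent, the step of a 1.1-fold lower number from compound 3 to compound 4 (0.04 log units; within the scatter) is expected to stay small, with no direction beyond the scatter.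

Compound 4 is therefore estimated at 350 ug/mL, with a range from 170 ug/mL to 720 ug/mL.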

Compound 4, half-maximal inhibitory concentration: 177 ug/mL
The estimate for compound 4 lay 2.0-fold (0.30 log units) above the measured number, and the stated range covers the measured number.
By their numbers in this assay, from the lowest: compounds 4, 1, 3 and 2 (each within the scatter of the next, the first and the last beyond it).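

At this position on the six-membered aromatic ring, this assay now shows its first step beyond the scatter, a modest one, when nitro takes the place of fluoro (a 2.2-fold lower number from compound 3 to compound 4 (0.34 log units; beyond the scatter)). Set against hydrogen at the same position, however, nitro gives no readable change (a 1.1-fold lower number from compound 1 to compound 4 (0.05 log units; within the scatter)), and fluoro against hydrogen also stays within the scatter (a 1.9-fold higher number from compound 1 to compound 3 (0.29 log units; within the scatter)), so the only readable difference here is the one between the nitro and fluoro compounds, and it is small. Nothing available gives a measured reason for that difference.

From the compounds shown here alone, only hydrogen, fluoro and nitro can be compared at this position on this core, so it remains open how an amine, a methoxy group or a carboxylic acid would behave there. Going by these compounds, it is also open whether the gap between nitro and fluoro would appear again with the different side chain carried by compound 2, or whether it would vanish on repeated measurement, given how little it exceeds the scatter.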